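The compounds below may be only part of what the source reports. "The series", "measured", "known", "first", "only" and "open" are said of these compounds alone.

Measured so far in a functional assay on A549 cells (Homo sapiens) for cytotoxicity, read by WST assay, with a stated time of 48 h; a higher number here means a weaker inhibitor, a lower number a stronger inhibitor:

compound 1, `COc1ccc2c(/C=C(\C#N)C(=O)c3c[nH]c4cc(F)ccc34)c[nH]c2c1`: 5500 nM
compound 2, `N#C/C(=C\c1c[nH]c2cc(F)ccc12)C(=O)c1c[nH]c2cc(F)ccc12`: 36100 nM
compound 3, `N#C/C(=C\c1cn(Cc2ccc(Cl)cc2)c2ccccc12)C(=O)c1c[nH]c2cc(F)ccc12`: for compound 3 this assay gives only a limit, > 50000 nM

Compound 1 and compound 2 share a core; the difference between them is methoxy in place of fluoro on an aromatic carbon. That change gives a 6.6-fold lower number from compound 2 to compound 1 (0.82 log units; beyond the scatter).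

Compound 3 and compound 2 differ in more than one place; the difference between the two cores is not broken down here. Compound 3 sits at the assay limit, a line at which one of the three values shown rests (the limit of > 50000 nM in this assay, at which 1 of the 3 values shown sits).

Compound 4, `COc1ccc2c(C(=O)/C(C#N)=C/c3cn(Cc4ccc(Cl)cc4)c4ccccc34)c[nH]c2c1`, is not yet measured. It differs from compound 3 by methoxy in place of fluoro on an aromatic carbon, the same change as from compound 2 to compound 1. With compound 3 only a limit, the expected step is an at least 1.6-fold lower number from compound 3 to compound 4 (0.22 log units; that floor lies within the scatter), the direction resting on a 6.6-fold lower number from compound 2 to compound 1 (0.82 log units; beyond the scatter), the size uncertain. Compound 4 is estimated at 30000 nM, expected between 9000 nM and 100000 nM.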

Compound 4, half-maximal inhibitory concentration: > 50000 nM
Compound 4 was reported as a limit (the forecaster's own chance of this, stated with the estimate: 45%); middle value at least 1.6-fold (0.22 log units) from the limit.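

Compound 3 and compound 4 both stand only as limits in this assay, so no step can be read between them: the limit of > 50000 nM in this assay, at which 2 of the 4 values shown sit.

From the compounds shown here alone, whether methoxy in place of fluoro lowers the number on the core of compound 3, as it does from compound 2 to compound 1, stays open.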